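Swapping the Outer Ring on a Very Poorly Soluble Series

This account rests on a few compounds, and the source may have more. Where it says the series, first, only, none or still open, it means among the compounds named here.

Three measured compounds share one core. In a physicochemical assay for solubility, read by HPLC, at pH 7 (on this read-out higher numbers stand for higher solubility and lower numbers for lower solubility), compound 1 `O=[N+]([O-])c1cn2c(n1)OC[C@@H](Oc1ccnc(-c3ccc(OC(F)(F)F)cc3)c1)C2` gives 0.53 ug/mL, compound 2 `O=[N+]([O-])c1cn2c(n1)OC[C@@H](OCCCC#Cc1ccc(OC(F)(F)F)cc1)C2` gives 0.09 ug/mL, and compound 3 `O=[N+]([O-])c1cn2c(n1)OC[C@@H](OC/C=C/c1ccc(OCc3ccccc3)cc1)C2` gives 0.06 ug/mL. Compound 3 sits at the low end of this assay: its gap to compound 2 lies within the scatter, while compound 1 stands beyond it with the higher number. Compound 4 `O=[N+]([O-])c1cn2c(n1)OC[C@@H](OC/C=C/c1ccc(-c3ccc(OC(F)(F)F)cc3)cc1)C2` differs from compound 3 in one place: 4-(trifluoromethoxy)phenyl in place of benzyloxy on an aromatic carbon. Among the compounds with values here, no measured pair shows this exact change, so the step from compound 3 to compound 4 is expected to be small, a 1.5-fold lower number from compound 3 to compound 4 (0.18 log units; within the scatter), likely without leaving the scatter. Compound 4 is therefore estimated at 0.04 ug/mL, within a range of 0.01 ug/mL to 0.15 ug/mL.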

Compound 4, solubility: 0.5 ug/mL
The estimate for compound 4 lay 13-fold (1.10 log units) below the measured number; measured number outside the range, above it.
By their numbers in this assay, from the lowest: compounds 3 and 2 (each within the scatter of the next); then compounds 4 and 1 (each within the scatter of the next).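

Putting 4-(trifluoromethoxy)phenyl in place of benzyloxy on this aromatic carbon gives an 8.3-fold higher number from compound 3 to compound 4 (0.92 log units; beyond the scatter) in this assay. Within the data shown here, the earlier compounds held no pair differing in one place, so this is the only direct evidence that a single change at this position can shift the read-out beyond the scatter. No measurement shown explains the size of this step.

Still open, on these data alone, is how an amine or a carboxylic acid on the same aromatic carbon would read. Also open, as far as these compounds go, is whether this swap gives a similar step on a different chain.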